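Swapping the Aryl Group on a Thiourea in Prostate Cancer Cells

This account rests on a few compounds, and the source may have more. Where it says the series, first, only, none or still open, it means among the compounds named here.

Measured compounds:
- compound 1, `CNC(=O)c1cc(Oc2cccc(NC(=S)Nc3ccc(Cl)cc3)c2)ccn1`: 24100 nM
- compound 2, `CC(C)NC(=O)c1cc(Oc2cccc(NC(=S)Nc3ccc(Cl)cc3)c2)ccn1`: 21200 nM

Both values come from a functional assay on PC-3 cells (Homo sapiens) for cytotoxicity, read by MTT assay, with a stated time of 48 h; a higher number here means a weaker inhibitor, a lower number a stronger inhibitor. Going by the values given here, compound 1 has the higher of the two numbers, but the only measured step, a 1.1-fold lower number from compound 1 to compound 2 (0.06 log units; within the scatter), is within the scatter, so the two compounds cannot be told apart.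

Compound 3, `CNC(=O)c1cc(Oc2cccc(NC(=S)Nc3cccc(C(F)(F)F)c3)c2)ccn1`, has not been measured. It differs from compound 1 by 3-(trifluoromethyl)phenyl in place of 4-chlorophenyl on an amide-type nitrogen. Among the compounds with values here, the one measured step concerns a different part of the molecule, the group on the other amide-type nitrogen, and it was within the scatter; no measured pair bears on the aryl group attached to the thiocarbonyl carbon. Without such a pair, the expectation for compound 3 rests on compound 1 alone, with a wide range and no confident direction. Compound 3 is expected to give about 15000 nM in this assay, between 5000 nM and 45000 nM, a step estimated at a 1.6-fold lower number from compound 1 to compound 3 (0.21 log units; within the scatter).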

Compound 3, half-maximal inhibitory concentration: 24500 nM
For compound 3 the middle estimate is 1.6-fold (0.21 log units) below the measured one; the measured number falls inside the stated range.
By their numbers in this assay, from the lowest: compounds 2, 1 and 3 (each within the scatter of the next).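

In this assay, 3-(trifluoromethyl)phenyl in place of 4-chlorophenyl on the amide-type nitrogen whose other neighbour is the thiocarbonyl carbon gives a 1.0-fold higher number from compound 1 to compound 3 (0.01 log units; within the scatter), so compound 1 and compound 3 cannot be told apart. The earlier step concerned only the other amide-type nitrogen, whereas this one shows that an aryl group of 10 heavy atoms and one of 7 at this position give numbers that do not separate. Nothing available explains why these two aryl groups read alike.

Going by these compounds, both groups are phenyl rings bearing halogen atoms, so it remains open whether an amine or a carboxylic acid on the ring, or a longer alkyl chain in place of the ring, would shift the number. Also open, on these data alone, is how the isopropyl group of compound 2 would combine with 3-(trifluoromethyl)phenyl.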